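A few compounds are considered here, and "the series" means these few. Any claim that something is new, unique, unknown or untested is made for them only; others in the source may bear on it.

Measured compounds in an ADME assay on 184B5 cells (Homo sapiens) for cytotoxicity, read by sulforhodamine B assay, with a stated time of 48 h; on this read-out higher numbers stand for weaker inhibition of growth and lower numbers for stronger inhibition of growth:

compound 1, `O=C1C(=O)N(CN2CCN(c3ccnc4cc(Cl)ccc34)CC2)c2cc(Cl)ccc21` — 47500 nM
compound 2, `O=C1C(=O)N(CN2CCN(c3ccnc4cc(Cl)ccc34)CC2)c2cc(Br)ccc21` — 33200 nM
compound 3, `NC(=S)N/N=C1/C(=O)N(CN2CCN(c3ccnc4cc(C(F)(F)F)ccc34)CC2)c2cccc(Cl)c21` — 87800 nM

Compounds 1 and 2 share one core and differ in a single place, (bromo in place of chloro on an aromatic carbon); this change gives a 1.4-fold lower number from compound 1 to compound 2 (0.16 log units; within the scatter). Compound 3 carries a different core, and how the two cores differ is not broken down here. Compound 4, `NC(=S)N/N=C1/C(=O)N(CN2CCN(c3ccnc4cc(C(F)(F)F)ccc34)CC2)c2cccc(Br)c21`, is the unmeasured partner of compound 3. The difference between compound 3 and compound 4 is bromo in place of chloro on an aromatic carbon. Its place is described as ortho to a fused ring and meta to a fused ring, whereas in the change from compound 1 to compound 2 the place is meta to a fused ring and para to a fused ring, so the two changes are of the same kind rather than the same. Among the compounds with values here, on the single precedent, a 1.4-fold lower number from compound 1 to compound 2 (0.16 log units; within the scatter), the expected step for compound 4 is a 1.4-fold lower number from compound 3 to compound 4 (0.14 log units; within the scatter). Compound 4 is therefore estimated at 63000 nM, in a range from 30000 nM to 130000 nM.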

Compound 4, concentration for 50% growth inhibition: 26400 nM
The estimate for compound 4 lay 2.4-fold (0.38 log units) above the measured number; measured number outside the range, below it.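

On the core of compound 3, bromo in place of chloro on an aromatic carbon gives a 3.3-fold lower number from compound 3 to compound 4 (0.52 log units; beyond the scatter) in this assay, a larger step than the earlier one, but the gap between them does not exceed what two such steps can scatter: the same change on two cores in this assay, a 1.4-fold lower number (0.16 log units; within the scatter) from compound 1 to compound 2 and a 3.3-fold lower number (0.52 log units; beyond the scatter) from compound 3 to compound 4, 2.3-fold (0.37 log units) apart, within the scatter of two such steps. The two cores therefore give no sign that the size of this change depends on the core. Two pairs, with the change at different places on the ring, cannot show that it carries over unchanged to further cores.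

The compounds shown leave open how an amine or a methoxy group would read in place of the halogen. They also leave open what this change would give at the same place on both cores.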